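From trifluoromethyl to fluoro on compound 2

A few compounds are considered here, and "the series" means these few. Any claim that something is new, unique, unknown or untested is made for them only; others in the source may bear on it.

In an ADME assay on MCF7-DOX cells (Homo sapiens) for cytotoxicity, read by MTT assay, with a stated time of 48 h (a lower number here means a stronger inhibitor, a higher number a weaker inhibitor), compound 1 (`COc1cc(O)c(C(=O)/C=C/c2ccc(N3CCNCC3)cc2)c(OC)c1`) gives 67500 nM and compound 2 (`COc1cc(OC)c(C(=O)/C=C/c2ccc(C(F)(F)F)cc2)c(O)c1CC=C(C)C`) gives 73700 nM while compound 3 (`COc1c(C)c(O)c(C)c(O)c1C(=O)/C=C/c1ccccc1`) gives 46800 nM in the same run of numbers. Compound 2 thus stands within the scatter of both other compounds. Compound 4 (`COc1cc(OC)c(C(=O)/C=C/c2ccc(F)cc2)c(O)c1CC=C(C)C`) is not yet measured. It carries fluoro in place of trifluoromethyl on an aromatic carbon, para to a large group. Among the compounds with values here, no measured pair differs in one place, so no direct precedent exists. With compound 2 at 73700 nM as the only anchor, no step beyond the scatter is expected in this assay. The estimated change is a 1.2-fold lower number from compound 2 to compound 4 (0.09 log units; within the scatter) and stays within the scatter. Compound 4 is expected at 60000 nM (estimated range 30000 nM to 110000 nM).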

Compound 4, half-maximal inhibitory concentration: 53700 nM
Compound 4: middle estimate off by 1.1-fold (0.05 log units), on the high side, within the range that was stated.
By their numbers in this assay, from the lowest: compounds 3, 4, 1 and 2 (each within the scatter of the next).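

In this assay, within the data shown here, the change from trifluoromethyl to fluoro gives a 1.4-fold lower number from compound 2 to compound 4 (0.14 log units; within the scatter) and provides the first comparison that differs in one place. On this aromatic carbon, the group can go from 4 heavy atoms to 1 without a step beyond the scatter. No measurement here explains this result. Going by these compounds, whether an amine or a carboxylic acid at this place would give a step beyond the scatter remains open. Also open, on these data alone, is whether the same change would behave alike on another core.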